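This account rests on a few compounds, and the source may have more. Where it says the series, first, only, none or still open, it means among the compounds named here.

Compound 3 `COc1ccc(S(=O)(=O)NCCN2CCC(CCC(=O)c3cc(Cl)c(N)cc3OC)CC2)cc1Br` gives 24.3 nM in an assay on brain for displacement of a labelled ligand from 5-hydroxytryptamine receptor 4 (Cavia porcellus), with a stated time of 30 min, in the presence of a further agent that is not named here (a lower number here means a stronger inhibitor, a higher number a weaker inhibitor), the highest of the three numbers shown, though its gap to compound 1 lies within the scatter. Compound 1 `COc1cc(N)c(Cl)cc1C(=O)CCC1CCN(CCNS(=O)(=O)c2cc(Br)ccc2Br)CC1` gives 16.3 nM in this assay, and compound 2 `COc1cc(N)c(Cl)cc1C(=O)CCC1CCN(CCNS(=O)(=O)c2ccc3c(c2)NC(=O)CO3)CC1` gives 6.2 nM. Among the measured steps, a 1.5-fold higher number from compound 1 to compound 3 (0.17 log units; within the scatter) changed the aromatic ring on the sulfonyl sulfur with little effect, while a 2.6-fold lower number from compound 1 to compound 2 (0.42 log units; beyond the scatter) and a 3.9-fold higher number from compound 2 to compound 3 (0.59 log units; beyond the scatter) were modest. Compound 4 `COc1ccc(S(=O)(=O)NCCN2CCC(CCC(=O)c3cc(Cl)c(N)cc3OC)CC2)cc1` differs from compound 3 in that (hydrogen in place of bromo on an aromatic carbon). Going by the values given here, no measured step removes a bromo alone, and the one step on the same ring stayed within the scatter, so only a small step is expected, a 1.3-fold higher number from compound 3 to compound 4 (0.12 log units; within the scatter), if anything toward a higher number. Compound 4 is therefore estimated at 32 nM, within 12 nM to 80 nM.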

Compound 4, inhibition constant: 12.3 nM
Estimate against measurement, compound 4: 2.6-fold (0.42 log units) above, within the range that was stated.
By their numbers in this assay, from the lowest: compounds 2, 4, 1 and 3 (each within the scatter of the next, the first and the last beyond it).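

Replacing the bromo with hydrogen on this aromatic carbon gives a 2.0-fold lower number from compound 3 to compound 4 (0.30 log units; within the scatter) in this assay and so shows that the bromo is not required for binding in the nanomolar range. The 4-methoxyphenyl group on the sulfonyl sulfur also does not separate from the other two groups there, with a 2.0-fold higher number from compound 2 to compound 4 (0.30 log units; within the scatter) and a 1.3-fold lower number from compound 1 to compound 4 (0.12 log units; within the scatter) both within the scatter. No evidence is available on what lies behind these results. The compounds shown leave open how a fluoro, a hydroxyl or an amine would read at this position, and what the methoxy group contributes.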